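Variation of the phenoxy group on the shared core

The source may report more compounds than this note shows. Statements on the series, on what has been measured and on what is new or still open speak of the compounds shown alone.

Compound 1 `Cc1ccc(Oc2cccc(COc3ccccc3CCC(=O)OCCCOP(=O)(O)OC[C@H](N)C(=O)O)c2)cc1` is the reference point of this set. In an assay on cells for agonist activity at probable G-protein coupled receptor 34 (Mus musculus), with a stated time of 1 h (on this read-out lower numbers stand for smaller maximal responses and higher numbers for larger maximal responses), compound 1 gives 18.2%, the second highest of the three numbers recorded so far, with compound 3 `N[C@@H](COP(=O)(O)OCCCOC(=O)CCc1ccccc1OCc1cccc(Oc2ccc(I)cc2)c1)C(=O)O` nearest at 19.1% and compound 2 `N[C@@H](COP(=O)(O)OCCCOC(=O)CCc1ccccc1OCc1cccc(Oc2cccc(Cl)c2)c1)C(=O)O` furthest at 17.1%. The steps among these three are all small: a number 0.9 percentage points higher from compound 1 to compound 3 (within the scatter), a number 1.1 percentage points lower from compound 1 to compound 2 (within the scatter) and a number 2 percentage points higher from compound 2 to compound 3 (within the scatter). Three different groups on the phenoxy part of the core thus gave maximal responses that cannot be told apart.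

Compound 4 `CC(C)(C)c1ccc(Oc2cccc(COc3ccccc3CCC(=O)OCCCOP(=O)(O)OC[C@H](N)C(=O)O)c2)cc1` keeps the shared core and changes one group: tert-butyl in place of methyl on an aromatic carbon. Among the measured compounds shown here, no step measured so far exchanges methyl for tert-butyl, so the closest guide is the whole picture of the three steps on the same phenoxy group, none of which moved the read-out beyond the scatter. A step no larger than these is therefore expected, with no direction favoured, so that compound 4 is estimated at a number 0.2 percentage points lower from compound 1 to compound 4 (within the scatter). The estimated value for compound 4 in this assay is 18%, with a range from 9% to 27%.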

Compound 4, largest response reached (Emax), in percent of the reference or control that the assay uses: 16.9%
Estimate against measurement, compound 4: 1.1 percentage points above; the measured number falls inside the stated range.
By their numbers in this assay, from the lowest: compounds 4, 2, 1 and 3 (each within the scatter of the next).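

Tert-butyl in place of methyl, on an aromatic carbon para to a large group, brings 4 heavy atoms where there was 1, and in this assay this gives a number 1.3 percentage points lower from compound 1 to compound 4 (within the scatter) and so adds a much bulkier substituent to the three-compound picture without moving the read-out beyond the scatter. The comparisons with the iodo and 3-chlorophenyl compounds agree, with a number 2.2 percentage points lower from compound 3 to compound 4 (within the scatter) and a number 0.2 percentage points lower from compound 2 to compound 4 (within the scatter), so all four compounds, now including methyl, chloro, iodo and tert-butyl variants, cannot be told apart on maximal response. Nothing available here bears on why the read-out stays this flat across these groups.

Still open, from the compounds shown here alone, is whether a group of a different kind on this aromatic carbon, such as a primary amine or a carboxylic acid in place of tert-butyl, would take the response beyond the scatter of the values seen so far. Also open is how the maximal response follows changes elsewhere on the shared core, for example an amide in place of its ester, since every change shown here stays on the phenoxy group.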